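The compounds below may be only part of what the source reports. "The series", "measured", "known", "first", "only" and "open" are said of these compounds alone.

Of the compounds shown here, two have so far been tested in a functional assay on HUVEC cells (Homo sapiens) for antiproliferative activity, read by MTT assay, with a stated time of 48 h; on this read-out lower numbers stand for stronger inhibition and higher numbers for weaker inhibition. Compound 1 (`O=[N+]([O-])c1ccccc1/C=C/c1nnc(-c2ccc3c(c2)OCCO3)o1`) gives 25000 nM, while compound 2 (`Fc1ccc(/C=C/c2nnc(-c3ccc4c(c3)OCCO4)o2)cc1`) gives 4960 nM, the lower number of the pair by a gap beyond the scatter. Compound 3 (`Fc1ccccc1/C=C/c1nnc(-c2ccc3c(c2)OCCO3)o1`) has not yet been measured. It has the same atoms as compound 2, joined differently: 2-fluorophenyl in place of 4-fluorophenyl on a double-bonded chain carbon bound to a double-bonded chain carbon. In words, 2-fluorophenyl stands in place of 4-fluorophenyl on a double-bonded chain carbon bound to a double-bonded chain carbon. For the measured compounds named here, no measured pair shows a change of this kind, so the expectation rests on thin evidence. Going by the values given here, compound 2, at 4960 nM, holds the lower of only two numbers, so a modest weakening is expected rather than a gain. The expected shift is estimated as a 1.5-fold higher number from compound 2 to compound 3 (0.18 log units; within the scatter). For compound 3 the estimated value in this assay is 7500 nM, with an expected range from 2500 nM to 22000 nM.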

Compound 3, half-maximal inhibitory concentration: 1160 nM
Compound 3: the middle estimate sits 6.5-fold (0.81 log units) above what was measured; measured number below the stated range.
By their numbers in this assay, from the lowest: compound 3; then compound 2; then compound 1.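

In this assay the place of the fluorine alone matters: 2-fluorophenyl in place of 4-fluorophenyl gives a 4.3-fold lower number from compound 2 to compound 3 (0.63 log units; beyond the scatter) with the atoms unchanged, which the earlier pair could not show. Fluoro in place of nitro on an aromatic carbon gives a 22-fold lower number from compound 1 to compound 3 (1.33 log units; beyond the scatter) and is the larger of the two steps, so the group held at that aromatic carbon also weighs heavily on this read-out. Nothing measured here accounts for either step.

The compounds shown leave open whether chloro, methoxy or an amine on that same aromatic carbon would match the fluoro of compound 3. They also leave open whether the gain from 2-fluorophenyl would survive if a saturated chain replaced the double-bonded chain.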